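The compounds below may be only part of what the source reports. "The series", "measured", "known", "first", "only" and "open" are said of these compounds alone.

Among the compounds with values here, in a functional assay on U-87MG ATCC cells for inhibition, with U-87 MG (Homo sapiens) as the target, read by sulforhodamine B assay, with a stated time of 72 h (on this read-out lower numbers stand for an effect already at smaller amounts and higher numbers for an effect only at larger amounts of compound), compound 1 `O=C(/C=C/c1ccc([N+](=O)[O-])o1)c1ccc(I)cc1` gives 5200 nM and compound 2 `CCCCc1ccc(C(=O)/C=C/c2ccc([N+](=O)[O-])o2)cc1` gives 5800 nM on the same scale, so compound 2 stands level with the only other measured compound, within the usual scatter. Compound 3 `O=C(/C=C/c1ccc([N+](=O)[O-])o1)c1ccc(-n2ccnc2)cc1` keeps the shared core and alters one group: 1H-imidazol-1-yl in place of butyl on an aromatic carbon with 1H-imidazol-1-yl in place of butyl on an aromatic carbon. Within the data shown here, only one measured step bears on this change: a 1.1-fold higher number from compound 1 to compound 2 (0.05 log units; within the scatter) when butyl replaces iodo on an aromatic carbon. That step is small, but neither compound 1 nor compound 2 carries a 1H-imidazol-1-yl group, so the evidence is thin and the range must stay wide. No step beyond the scatter is therefore expected in this assay for this change. The expected shift is a 1.2-fold lower number from compound 2 to compound 3 (0.06 log units; within the scatter) in this estimate. For compound 3 the estimated value is 5000 nM with an expected range from 1800 nM to 14000 nM in all.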

Compound 3, half-maximal effective concentration: 13400 nM
Compound 3: the middle estimate sits 2.7-fold (0.43 log units) below what was measured; the range from low to high includes it.
By their numbers in this assay, from the lowest: compounds 1 and 2 (each within the scatter of the next); then compound 3.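

In this assay this place on the six-membered aromatic ring proves sensitive to what it carries: 1H-imidazol-1-yl gives a 2.3-fold higher number from compound 2 to compound 3 (0.36 log units; beyond the scatter) when it replaces butyl and a 2.6-fold higher number from compound 1 to compound 3 (0.41 log units; beyond the scatter) when it replaces iodo. Within the data shown here, both steps are modest but beyond the scatter, whereas the change from iodo to butyl stayed within it, so two quite different groups sit level here and the imidazole ring is the first change to need more compound for the same effect. No measurement shown here gives a reason for this shift.

As far as these compounds go, it remains open whether the loss follows from the imidazole ring in particular or would also appear with a phenyl ring, an amine or a carboxylic acid at this place. Whether a group at this place can lower the number also stays unanswered.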